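The source may report more compounds than this note shows. Statements on the series, on what has been measured and on what is new or still open speak of the compounds shown alone.

Measured in a functional assay on ECa-109 cells for inhibition, with ECa-109 cell line (Homo sapiens) as the target, read by sulforhodamine B assay; on this read-out lower numbers stand for stronger inhibition and higher numbers for weaker inhibition:

- Compound 1 `O=C1C=C(NCc2ccccc2)C(=O)c2c1nc1n2[C@H]2OC[C@@H](O)[C@H]2OC1`: > 8000 nM
- Compound 2 `Cc1ccc(NC2=CC(=O)c3c(nc4n3[C@H]3OC[C@@H](O)[C@H]3OC4)C2=O)cc1`: > 4000 nM
- Compound 3 `O=C1C(N2CCCCC2)=CC(=O)c2c1nc1n2[C@H]2OC[C@@H](O)[C@H]2OC1`: > 8000 nM

The value of compound 1 is a limit and not a number. Its place is the limit of > 8000 nM in this assay, at which 2 of the 3 values shown sit. The remaining value is the limit of > 4000 nM in this assay, at which 1 of the 3 values shown sits, and it belongs to compound 2. Within the data shown here, no compound in this set therefore has an exact number yet.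

Compound 4 `O=C1C=C(Nc2ccc(Br)cc2)C(=O)c2c1nc1n2[C@H]2OC[C@@H](O)[C@H]2OC1` differs from compound 1 by having 4-bromophenyl in place of benzyl on an amine nitrogen. The same difference, cut one bond further out, reads benzylamino to (4-bromophenyl)amino. The only measured step among these compounds is a step that the two limits leave unreadable from compound 2 to compound 3, so it offers no size to carry over. Compound 2, with its (4-methylphenyl)amino group, is the closest measured comparison, and its value of > 4000 nM is also a limit. No step beyond the usual scatter is expected in this assay, in either direction. The expected step is an at least 1.1-fold lower number from compound 1 to compound 4 (0.05 log units; that floor lies within the scatter). For compound 4 the estimate is 7000 nM, with an expected range of 2500 nM to 16000 nM.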

Compound 4, half-maximal inhibitory concentration: 2850 nM
Compound 4: the middle estimate sits 2.5-fold (0.39 log units) above what was measured; the measured number falls inside the stated range.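

In this assay, among these compounds, putting 4-bromophenyl in place of benzyl on the amine nitrogen gives an at least 2.8-fold lower number from compound 1 to compound 4 (0.44 log units; beyond the scatter), the first change on the shared core whose size can be read, and compound 4 is the first compound here with an exact number. The value of compound 1, > 8000 nM, is a limit, so this size is only a floor. Nothing measured here explains the step.

The change swaps the carbon link for a direct bond to the ring and adds bromine in one move, so the compounds shown cannot separate the two. A plain phenyl on the same nitrogen would tell them apart, and a chlorine or a methoxy in place of the bromine would show how much depends on that atom.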